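Working notes: from chloro to dimethylamino

A few compounds are considered here, and "the series" means these few. Any claim that something is new, unique, unknown or untested is made for them only; others in the source may bear on it.

Measured in a physicochemical assay for lipophilicity; on this read-out higher numbers stand for higher lipophilicity and lower numbers for lower lipophilicity:
- compound 1 `CN(C)c1ccc(/C=C2\CCC/C(=C\c3cccc([N+](=O)[O-])c3)C2=O)cc1`: 5
- compound 2 `O=C1/C(=C/c2ccccc2)CCC/C1=C\c1ccc([N+](=O)[O-])cc1`: 4.93
- compound 3 `O=C1/C(=C/c2ccc(Cl)cc2)CCC/C1=C\c1ccc([N+](=O)[O-])cc1`: 5.6

Compound 3 stands highest of the three at 5.6. Compound 1 is nearest at 5, and compound 2 is furthest at 4.93. Both gaps lie beyond the scatter.

The next compound to be measured is compound 4 `CN(C)c1ccc(/C=C2\CCC/C(=C\c3ccc([N+](=O)[O-])cc3)C2=O)cc1`. It follows from compound 3 by one change: dimethylamino in place of chloro on an aromatic carbon. Dimethylamino takes the place of chloro on an aromatic carbon, para to a large group.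

Going by the values given here, only one measured step bears directly on this position, chloro in place of hydrogen: a number 0.67 log units higher from compound 2 to compound 3 (beyond the scatter). This is a modest step, and it shows what the arrival of chloro went with, not what the loss of chloro alongside the arrival of dimethylamino will do. Among the compounds with values here, no measured step has dimethylamino entering. The closest evidence is compound 1, which also carries the 4-(dimethylamino)phenyl group and gives 5. A modest fall in this assay is therefore expected, smaller than or similar to the chloro step: a number 0.50 log units lower from compound 3 to compound 4 (beyond the scatter). For compound 4 the estimated value is 5.1, with an expected range of 4.7 to 5.5.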

Compound 4, partition coefficient: 5.03
Estimate against measurement, compound 4: 0.07 log units above, and the stated range covers the measured number.
By their numbers in this assay, from the lowest: compounds 2, 1 and 4 (each within the scatter of the next); then compound 3.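

Notes on compound 4

In this assay, the change from 4-chlorophenyl to 4-(dimethylamino)phenyl gives a number 0.57 log units lower from compound 3 to compound 4 (beyond the scatter) and so, at this position, the higher number seen with chloro is not kept when dimethylamino takes its place. Against hydrogen at the same aromatic carbon, dimethylamino gives a number 0.10 log units higher from compound 2 to compound 4 (within the scatter) and stays within the scatter, whereas chloro gave a number 0.67 log units higher from compound 2 to compound 3 (beyond the scatter) and lay beyond it, so the two groups now part company on this read-out when each is compared with the same unsubstituted compound. Going by these compounds alone, a second position also becomes readable for the first time, with dimethylamino held constant: 4-nitrophenyl in place of 3-nitrophenyl gives a number 0.03 log units higher from compound 1 to compound 4 (within the scatter) and this too stays within the scatter, so the two nitrophenyl placings are not separated in this pair.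

Going by these compounds, it remains open whether a smaller amine such as the unsubstituted amino group, or a methoxy group, at this same aromatic carbon would also stay level with hydrogen or would move as chloro did. Within the data shown here, nothing measured so far offers any explanation of why these steps take the sizes they do.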